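A cyclopropyl group added to compound 3

This account rests on a few compounds, and the source may have more. Where it says the series, first, only, none or still open, it means among the compounds named here.

Compound 1 `O=C(NC1CC1)C1CCN(c2cnccc2-c2ccccc2)CC1` gives 2.5
Compound 2 `CN(C)C(=O)C1CCN(c2cncnc2-c2ccccc2)CC1` gives 1.7
Compound 3 `CN(C)C(=O)C1CCN(c2cnccc2-n2cccn2)CC1` gives 1.1

In a physicochemical assay for lipophilicity, at pH 7.4 (a higher number here means a more lipophilic compound, a lower number a more polar compound), compound 3 reads 1.1 and stands lowest of the three. Compound 2 at 1.7 lies nearest to it and compound 1 at 2.5 lies furthest, and both gaps are beyond the usual scatter.

Compound 4 `CN(C)C(=O)C1CCN(c2cnccc2-n2cc(C3CC3)cn2)CC1` has not yet been measured. It differs from compound 3 in one place, an aromatic carbon of a five-membered aromatic ring with 2 nitrogen, where cyclopropyl stands in place of hydrogen (cyclopropyl in place of hydrogen on an aromatic carbon). The 1H-pyrazol-1-yl group thus becomes 4-cyclopropyl-1H-pyrazol-1-yl.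

Within the data shown here, no two measured compounds differ in only one place, so the data offer no direct precedent for this change, and the expectation rests on the structural change alone. The estimated step is a number 0.90 log units higher from compound 3 to compound 4 (beyond the scatter) and points to a higher number, beyond the scatter. In this assay compound 4 is expected at 2 with a range from 1.6 to 2.4 as estimated here.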

Compound 4, distribution coefficient: 2.1
For compound 4 the middle estimate is 0.10 log units below the measured one, within the range that was stated.
By their numbers in this assay, from the lowest: compound 3; then compound 2; then compound 4; then compound 1.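

In this assay, among these compounds, the pair compound 3 and compound 4 gives the first reading of a single change. Compound 1 and compound 2 each differ from compound 3 in more than one place. Cyclopropyl in place of hydrogen on an aromatic carbon, two ring bonds from the ring nitrogen, gives a number 1.00 log units higher from compound 3 to compound 4 (beyond the scatter), so this one position of the 1H-pyrazol-1-yl group alone moves the number beyond the scatter. Nothing measured here accounts for the size of that step.

Going by these compounds, it remains open whether a methyl group, a longer chain or an amine on the same aromatic carbon would give a step of like size. On these data alone, it is equally open whether cyclopropyl on another carbon of this ring would do so.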